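This account rests on a few compounds, and the source may have more. Where it says the series, first, only, none or still open, it means among the compounds named here.

Measured in a functional assay on A549 cells (Homo sapiens) for antiproliferative activity, read by MTT assay, with a stated time of 72 h; on this read-out lower numbers stand for stronger inhibition and higher numbers for weaker inhibition:
Compound 1 `COc1cc2ncnc(Nc3cccc(F)c3)c2cc1OCCCN1CCNCCNCCNCC1`: > 50000 nM (a limit)
Compound 2 `COc1cc2ncnc(Nc3ccc(Cl)c(C(F)(F)F)c3)c2cc1OCCCN1CCNCCNCC1`: 6230 nM
Compound 3 `COc1cc2ncnc(Nc3cccc(Cl)c3)c2cc1OCCCN1CCNCCNCC1`: > 50000 nM (a limit)

Compound 3 gives no number, only the limit > 50000 nM. This is the limit of > 50000 nM in this assay, at which 2 of the 3 values shown sit. Compound 4 `COc1cc2ncnc(Nc3cccc(F)c3)c2cc1OCCCN1CCNCCNCC1` carries fluoro in place of chloro on an aromatic carbon, meta to a large group: fluoro in place of chloro on an aromatic carbon. Among the measured compounds shown here, the one measured step on this aromatic ring is an at least 8.0-fold higher number from compound 2 to compound 3 (0.90 log units; beyond the scatter), a change from 4-chloro-3-(trifluoromethyl)phenyl to 3-chlorophenyl. Compound 1, which also carries 3-fluorophenyl, gives only the limit > 50000 nM. In this assay, no change beyond the scatter is expected, and the expected step is a number no higher from compound 3 to compound 4 (the limit leaves the size open). Compound 4 is estimated at 50000 nM, within an expected range of 20000 nM to 100000 nM, and may well be reported only as a limit.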

Compound 4, half-maximal inhibitory concentration: > 50000 nM
Compound 4: only a limit was reported (the forecaster's own chance of this, stated with the estimate: 70%); the middle value lies on the limit itself.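

In this assay compound 4 gives > 50000 nM, a limit and not a number. With 3-fluorophenyl in place of 4-chloro-3-(trifluoromethyl)phenyl, the record shows an at least 8.0-fold higher number from compound 2 to compound 4 (0.90 log units; beyond the scatter), so the single-halogen ring falls short of compound 2 with fluoro as well as with chloro. The steps to compound 4 from compound 3 and from compound 1 cannot be read, and the series gathers at one ceiling: the limit of > 50000 nM in this assay, at which 3 of the 4 values shown sit.

Going by these compounds, how fluoro and chloro differ on this aromatic carbon stays open. So does whether 3-(trifluoromethyl)phenyl or 4-chlorophenyl alone would give a measurable number on this ring-bearing chain.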